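Selenium to tellurium: a step from an assay limit

The source may report more compounds than this note shows. Statements on the series, on what has been measured and on what is new or still open speak of the compounds shown alone.

Measured so far in a functional assay on SK-MEL-147 cells (Homo sapiens) for cytotoxicity, read by MTT assay, with a stated time of 24 h; a lower number here means that less compound is needed, a higher number that more compound is needed for the effect:
- Compound 1 `CCOC(=O)c1cc([Se]Cc2ccccc2)c2cc(OC)ccc2n1`: 40700 nM
- Compound 2 `CCOC(=O)c1cc([Se]c2ccc(F)cc2)c2cc(OC)ccc2n1`: > 150000 nM (a limit, not a number)

Compound 2 stands at > 150000 nM, which is a limit of this assay and not a number. This is the limit of > 150000 nM in this assay, at which 1 of the 2 values shown sits. Compound 3 `CCOC(=O)c1cc([Te]c2ccccc2)c2cc(OC)ccc2n1` differs from compound 2 as follows: a group of 7 heavy atoms (6 carbon, 1 tellurium; one six-membered aromatic ring of carbon only) in place of a group of 8 heavy atoms (6 carbon, 1 fluorine, 1 selenium; one six-membered aromatic ring of carbon only), on an aromatic carbon. The change sits on an aromatic carbon, opposite the ring nitrogen.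

Within the data shown here, only one measured step is available, an at least 3.6-fold higher number from compound 1 to compound 2 (0.56 log units; beyond the scatter), with 4-fluorophenyl in place of benzyl on a selenium. Among the measured compounds shown here, it bears on the new change only indirectly, as no measured pair swaps selenium for tellurium or removes the fluorine. Compound 2 gives no exact starting point, so any number measured for compound 3 would have to be lower, although it could also stay at the limit. For the measured compounds named here, compound 1, at 40700 nM, is the only exact value for comparison. The expected size of the change is an at least 2.5-fold lower number from compound 2 to compound 3 (0.39 log units; beyond the scatter). For compound 3 the estimated value is 60000 nM, with an expected range of 12000 nM to 150000 nM.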

Compound 3, half-maximal effective concentration: 128000 nM
Beside the measured number, compound 3's estimate is 2.1-fold (0.33 log units) below it; the range from low to high includes it.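

In this assay, compound 3 gives an exact number for a six-membered aromatic ring held directly on tellurium at this position, opposite the ring nitrogen, and the change from benzyl on selenium gives a 3.1-fold higher number from compound 1 to compound 3 (0.50 log units; beyond the scatter), so both compounds with the ring held directly on the heavy atom sit on the high side of the benzyl compound. The other comparison reads only as an at least 1.1-fold lower number from compound 2 to compound 3 (0.06 log units; that floor lies within the scatter), which leaves open whether the swap of selenium and fluorophenyl for tellurium and phenyl changes the number at all. That step stays so loose because compound 2 holds a limit of the assay and not a number: the limit of > 150000 nM in this assay, at which 1 of the 3 values shown sits.

Two things change at once between compound 2 and compound 3, so the compounds shown cannot separate the effect of the tellurium from that of the lost fluorine; a plain phenyl on selenium, or a 4-fluorophenyl or a benzyl on tellurium, would pull them apart. As far as these compounds go, it also stays open how this position answers to a group of another kind on the selenium or tellurium, such as a longer carbon chain or a chain ending in an amine.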